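This account rests on a few compounds, and the source may have more. Where it says the series, first, only, none or still open, it means among the compounds named here.

Measured compounds in an ADME assay on HT-29 cells (Homo sapiens) for inhibition, read by MTT assay, with a stated time of 72 h; a lower number here means a stronger inhibitor, a higher number a weaker inhibitor:
compound 1 `C=CC(=O)Nc1cccc(Nc2nc(N/N=C(\C)c3ccc(C)cc3)ncc2Cl)c1`: 3210 nM
compound 2 `C=CC(=O)Nc1cccc(Nc2nc(N/N=C(\C)c3cccc(OC)c3)ncc2Cl)c1`: 8990 nM
compound 3 `CN(C)C/C=C/C(=O)Nc1cccc(Nc2nc(N/N=C/c3ccncc3)ncc2Cl)c1`: 25200 nM

Compound 3 gives the highest number of the three; the nearest, compound 2, is lower, and compound 1 lower still, both gaps beyond the scatter. Compound 4 `C/C(=N\Nc1ncc(Cl)c(Nc2cccc(NC(=O)/C=C/CN(C)C)c2)n1)c1ccncc1` differs from compound 3 in one place: a group of 9 heavy atoms (7 carbon, 2 nitrogen; one six-membered aromatic ring with 1 hetero atom) in place of a group of 8 heavy atoms (6 carbon, 2 nitrogen; one six-membered aromatic ring with 1 hetero atom), on a nitrogen on an aromatic ring. For the measured compounds named here, no measured step covers this change; the only one-place step, a 2.8-fold higher number from compound 1 to compound 2 (0.45 log units; beyond the scatter), concerns a different part of the molecule. Compounds 1 and 2 carry a methyl on the carbon with a double bond to nitrogen, as compound 4 does, but they differ from compound 3 in more than one place, so their lower numbers give only weak guidance. A modest fall, or no step beyond the scatter, is expected: a 1.9-fold lower number from compound 3 to compound 4 (0.29 log units; within the scatter). Compound 4 is estimated at 13000 nM (range 4000 nM to 40000 nM).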

Compound 4, half-maximal inhibitory concentration: 10900 nM
The estimate for compound 4 lay 1.2-fold (0.08 log units) above the measured number; the range from low to high includes it.
By their numbers in this assay, from the lowest: compound 1; then compounds 2 and 4 (each within the scatter of the next); then compound 3.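

In this assay, for the compounds shown here, placing a methyl on the carbon with a double bond to nitrogen gives a 2.3-fold lower number from compound 3 to compound 4 (0.36 log units; beyond the scatter) and is the only one-place reading at this position. The step shows that this single added methyl moves the number beyond the scatter, though only modestly. No available evidence accounts for the step. Still open, from the compounds shown here alone, is whether an ethyl or a cyclopropyl on that carbon would extend the step or reverse it. Also open, going by these compounds, is whether the methyl step would carry over to compounds with other aromatic rings at this position.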